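The compounds below may be only part of what the source reports. "The series", "measured", "known", "first", "only" and "open" are said of these compounds alone.

Going by the values given here, compound 1 `Cc1nc(-c2ccccc2)c(C(=O)N2CCN(c3cccc(C#N)c3)CC2)o1` carries the only reported number here: in a functional assay on HL-60 cells (Homo sapiens) for inhibition, read by MTT assay, with a stated time of 72 h (a higher number here means a weaker inhibitor, a lower number a stronger inhibitor), compound 1 gives 39.6 nM. Among the compounds with values here, compound 2 `O=C(c1oc(C(F)(F)F)nc1-c1ccc(F)cc1)N1CCN(c2cccc(Cl)c2)CC1` is reported in this assay as "not active" (no number reported), with no number given; it differs from compound 1 in more than one place, so the two give no single step. Compound 3 `Cc1nc(-c2ccccc2)c(C(=O)N2CCN(c3ccc(F)cc3)CC2)o1` changes compound 1 in one place: 4-fluorophenyl in place of 3-cyanophenyl on an amine nitrogen in a ring. Within the data shown here, no measured step covers this change. A modest weakening, just beyond the scatter, is expected, so that for compound 3 the expected step is a 2.5-fold higher number from compound 1 to compound 3 (0.40 log units; beyond the scatter). Compound 3 is expected to give about 100 nM, between 30 nM and 400 nM.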

Compound 3, half-maximal inhibitory concentration: > 1000 nM
Compound 3: a limit, no number; the forecaster's own chance of this, stated with the estimate: 15%; middle value at least 10-fold (1.00 log units) from the limit.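

In this assay, the group on the amine nitrogen of the six-membered ring matters: 4-fluorophenyl in place of 3-cyanophenyl gives an at least 25-fold higher number from compound 1 to compound 3 (1.40 log units; beyond the scatter). For compound 3, > 1000 nM is a limit and not a number. This single step changes both the substituent and its printed ring position, so it cannot assign the loss to either one.

4-Cyanophenyl and 3-fluorophenyl at this nitrogen remain open as the pair that would separate those two changes. Plain phenyl, with neither nitrile nor fluorine, also remains open on the shared core.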